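Chloro to Cyclohexylamino: One Step Beyond Compound 3

The compounds below may be only part of what the source reports. "The series", "measured", "known", "first", "only" and "open" are said of these compounds alone.

Measured so far in a functional assay on PC-3 cells (Homo sapiens) for cytotoxicity, read by MTT assay, with a stated time of 48 h; on this read-out lower numbers stand for stronger inhibition and higher numbers for weaker inhibition:
Compound 1, `CC1=NN(C(=O)c2ccc([N+](=O)[O-])cc2)C(c2ccccc2O)C1`, gives 36600 nM.
Compound 2, `CC(=O)Oc1ccccc1C1CC(C)=NN1C(=O)CN1CCCCC1`, gives 4070 nM.
Compound 3, `O=C(CCl)N1N=C(c2cc3ccccc3oc2=O)CC1c1ccccc1`, gives 2980 nM.

Compound 3 has the lowest number of the three. Its nearest neighbour on this read-out is compound 2, whose number is higher, but the gap lies within the usual scatter, so the two cannot be told apart. Compound 1 sits far higher, and that gap is beyond the scatter.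

Compound 4, `O=C(CNC1CCCCC1)N1N=C(c2cc3ccccc3oc2=O)CC1c1ccccc1`, has not yet been measured. It differs from compound 3 in a single place: cyclohexylamino in place of chloro on a saturated chain carbon bound to a carbonyl carbon. Within the data shown here, no pair of measured compounds reproduces this exact change, so there is no directly comparable step to lean on. What the data do show is that compound 2, which also carries a group bearing nitrogen on the saturated chain carbon bound to the carbonyl carbon, stands close to compound 3 in this assay.

On that basis the step from compound 3 to compound 4 is expected to be modest, a 1.2-fold lower number from compound 3 to compound 4 (0.08 log units; within the scatter), with no direction that can be called beyond the scatter. Compound 4 is estimated at 2500 nM, with a range from 800 nM to 8000 nM.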

Compound 4, half-maximal inhibitory concentration: 48500 nM
The estimate for compound 4 lay 19-fold (1.29 log units) below the measured number; measured number above the stated range.
By their numbers in this assay, from the lowest: compounds 3 and 2 (each within the scatter of the next); then compounds 1 and 4 (each within the scatter of the next).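

In this assay, putting cyclohexylamino in place of chloro on a saturated chain carbon bound to a carbonyl carbon gives a 16-fold higher number from compound 3 to compound 4 (1.21 log units; beyond the scatter), a large step beyond the scatter. With the rest of the molecule unchanged, this single position can therefore move the read-out strongly, and here a larger amine-bearing group goes with a much weaker result than chloro. The earlier compounds could not show this, since no two of them differ in one place only, and nothing shown bears on the reason for the step.

Among these compounds, the change also swaps a lone chlorine for a group that brings a carbon ring, a nitrogen and a hydrogen-bond donor together, so the single pair cannot separate what each of these contributes. Open too, going by these compounds, is where smaller replacements would fall on this scale, such as methylamino, which keeps the nitrogen without the ring, or cyclohexyl, which keeps the ring without the nitrogen, and whether either would stay close to compound 3 or rise towards compound 4.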